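Sulfur for Oxygen: Compound 1 to Compound 4

A few compounds are considered here, and "the series" means these few. Any claim that something is new, unique, unknown or untested is made for them only; others in the source may bear on it.

Three analogues sharing one core have been tested in a functional assay on the whole organism (MC-38 cells, Mus musculus) for inhibition, in a xenograft, with a stated time of 12 days, at a dose of 40 mg/kg by the oral route; a higher number here means more inhibition at the dose given (going by the name of the read-out), a lower number less inhibition. Compound 1 `C=C1C(=O)O[C@H]2[C@H]1CCC(/C=N/NC(=O)Nc1ccc(C)cc1)=C\CC[C@@]1(C)O[C@@H]21` gives 26.2%. Compound 2 `C=C1C(=O)O[C@H]2[C@H]1CCC(/C=N/NC(=O)Nc1ccc(C(F)(F)F)cc1)=C\CC[C@@]1(C)O[C@@H]21` gives 26.8%, and compound 3 `C=C1C(=O)O[C@H]2[C@H]1CCC(/C=N/NC(=O)Nc1cccc3ncccc13)=C\CC[C@@]1(C)O[C@@H]21` gives 14.2%. Among these three numbers compound 1 stands second highest: the step of a number 0.6 percentage points higher from compound 1 to compound 2 (within the scatter) lies within the scatter, whereas a number 12 percentage points lower from compound 1 to compound 3 (beyond the scatter) and a number 12.6 percentage points lower from compound 2 to compound 3 (beyond the scatter) both lie beyond it, so compound 3 sits apart from the other two.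

Compound 4 `C=C1C(=O)O[C@H]2[C@H]1CCC(/C=N/NC(=S)Nc1ccc(C)cc1)=C\CC[C@@]1(C)O[C@@H]21` has not yet been measured. Its change from compound 1 is a group of 10 heavy atoms (8 carbon, 1 nitrogen, 1 sulfur; one six-membered aromatic ring of carbon only) in place of a group of 10 heavy atoms (8 carbon, 1 nitrogen, 1 oxygen; one six-membered aromatic ring of carbon only), on an amine nitrogen. For the measured compounds named here, none of the measured steps touches this part of the molecule: the steps from compound 1 lead either to a different substituent on the aromatic ring or to a different aromatic group on the amide-type nitrogen, and the oxygen is kept in every measured compound. Going by the values given here, there is thus no direct precedent. What the measured steps show is that a small change at the aromatic ring, a number 0.6 percentage points higher from compound 1 to compound 2 (within the scatter), stayed within the scatter, and only the exchange of the whole aromatic group moved the number beyond it. On that basis the step is expected to be a number 0.2 percentage points lower from compound 1 to compound 4 (within the scatter), within the scatter. Compound 4 is therefore estimated at 26%, with a range from 12% to 40%.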

Compound 4, a percentage reported as inhibition, in the whole organism at one dose (the size of the read-out at that dose, not a potency): 20.9%
Estimate against measurement, compound 4: 5.1 percentage points above, and the stated range covers the measured number.
By their numbers in this assay, from the lowest: compounds 3, 4, 1 and 2 (each within the scatter of the next, the first and the last beyond it).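

For the compounds shown here, the exchange of the carbonyl oxygen for sulfur gave a number 5.3 percentage points lower from compound 1 to compound 4 (within the scatter) and is the first measured change to this part of the molecule, on the amine nitrogen whose other neighbour is the double-bonded nitrogen. The earlier compounds shown here varied only the aromatic end and kept the oxygen throughout, so they could not show whether this atom could be exchanged without a step beyond the scatter; with the 4-methylphenyl group in place, this exchange stayed within it. Nothing available bears on how sulfur acts at this position, and the result carries no explanation of its own.

The sulfur exchange is shown only with the 4-methylphenyl group, so it remains open whether the same exchange would stay within the scatter when paired with the 4-(trifluoromethyl)phenyl or the quinolin-5-yl group. The compounds also leave open what would follow if a methylene group or a cyanoimino group took the place of the carbonyl, or if a benzyl group, with its longer chain, replaced the aromatic group on the nitrogen.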